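Removing a ring fluorine from a weak modulator of a glutamate receptor

The source may report more compounds than this note shows. Statements on the series, on what has been measured and on what is new or still open speak of the compounds shown alone.

Measured so far:
compound 1 `O=C(N1CCC(F)CC1)N1CC(c2nc(-c3cccc(Cl)c3)no2)C1` — > 10000 nM
compound 2 `O=C(C1CCC(C(F)(F)F)CC1)N1CC(c2nc(-c3cccc(F)c3)no2)C1` — > 10000 nM
compound 3 `Cc1ccc(S(=O)(=O)N2CC(c3nc(-c4cccc(C)c4)no3)C2)cc1` — 670 nM

Of the compounds shown here, three sharing one core have been tested in an assay on HEK293 cells for negative allosteric modulation of metabotropic glutamate receptor 5 (Homo sapiens), read by FLIPR; on this read-out lower numbers stand for stronger inhibition and higher numbers for weaker inhibition. Compound 1 returned only a limit of the assay, > 10000 nM. Compound 2 also returned only a limit, > 10000 nM. Compound 3 gave a real number, 670 nM. Compound 1 therefore stands at the weak end of what has been seen: it sits at the limit of > 10000 nM in this assay, at which 2 of the 3 values shown sit, together with compound 2, while compound 3 alone shows measurable inhibition.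

The next compound, compound 4 `O=C(N1CCCCC1)N1CC(c2nc(-c3cccc(Cl)c3)no2)C1`, differs from compound 1 in one place: hydrogen in place of fluoro on a saturated ring carbon.

Among the compounds with values here, no pair of measured compounds differs in just one place, so there is no measured step to lean on. Compound 1 already lies at a limit, and the change is small. The expected step from compound 1 to compound 4 in this assay is a step that the limit leaves unreadable from compound 1 to compound 4, that is, none beyond the scatter. Compound 4 is therefore estimated at 15000 nM, with a range from 5000 nM to 50000 nM, and most likely another limit.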

Compound 4, half-maximal inhibitory concentration: > 10000 nM
Compound 4 ended at the assay's limit; the forecaster's own chance of this, stated with the estimate: 75%; the middle value is on the limit's open side.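

In this assay, compound 1 and compound 4 both ended at a limit rather than a real number, so no step between them can be read, and the results remain crowded at one point: the limit of > 10000 nM in this assay, at which 3 of the 4 values shown sit.

Left open is whether 4-fluoropiperidin-1-yl and piperidin-1-yl differ at all on a compound that gives a real number.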